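The source may hold more compounds than are shown below. What is called first, only, known or untested is meant among the compounds shown, and "the series" means these compounds.

Compounds measured in an assay on cells for inhibition of Amine oxidase [flavin-containing] B (Homo sapiens), read by fluorescence, with a stated time of 30 min, tested at 10 uM; on this read-out higher numbers stand for more inhibition at the one concentration tested (going by the name of the read-out) and lower numbers for less inhibition:
compound 1 `COc1ccccc1CN(C)Cc1ccc(/C=C2\Oc3cc(OC)c(OC)cc3C2=O)cc1O` gives 8.4%
compound 2 `COc1cc2c(cc1OC)C(=O)/C(=C/c1ccc(CN(C)Cc3ccccc3)c(O)c1)O2` gives 17.8%
compound 3 `COc1cc2c(cc1OC)C(=O)/C(=C/c1cccc(O)c1)O2` gives 37%

Compound 3 stands highest of the three numbers in this assay, with compound 2 nearest and compound 1 furthest below it. Compound 4 `CCN(CC)Cc1ccc(/C=C2\Oc3cc(OC)c(OC)cc3C2=O)cc1O` differs from compound 3 by (diethylamino)methyl in place of hydrogen on an aromatic carbon. Among the compounds with values here, the one step that bears on this change is a number 19.2 percentage points higher from compound 2 to compound 3 (beyond the scatter), where removal of an aminomethyl group raised the number; compound 4 reinstates such a group, though a smaller one. A drop of roughly that size, in the opposite direction, is therefore expected in this assay, beyond the scatter but modest. Compound 4 is estimated at 22%, between 8% and 38%, a step of a number 15 percentage points lower from compound 3 to compound 4 (beyond the scatter).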

Compound 4, a percentage reported as inhibition, at one concentration (the size of the read-out at that concentration, not a potency): 7.2%
Beside the measured number, compound 4's estimate is 14.8 percentage points above it; the measured number lies below the stated range.
By their numbers in this assay, from the lowest: compounds 4, 1 and 2 (each within the scatter of the next, the first and the last beyond it); then compound 3.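

In this assay, (diethylamino)methyl on this aromatic carbon, ortho to a hydroxy group, brings a number 29.8 percentage points lower from compound 3 to compound 4 (beyond the scatter), so an aminomethyl group with no ring also goes with a lower number here. Diethylamino in place of benzyl(methyl)amino brings a number 10.6 percentage points lower from compound 2 to compound 4 (beyond the scatter), while in place of (2-methoxybenzyl)(methyl)amino it brings a number 1.2 percentage points lower from compound 1 to compound 4 (within the scatter). The data shown offer no measurement that accounts for these results.

On these data alone, it remains open whether a primary aminomethyl, a morpholinylmethyl or a plain methyl group on this carbon would keep the number near that of compound 3.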